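Methoxy to hydroxy on a shared pyrazole urea scaffold

A few compounds are considered here, and "the series" means these few. Any claim that something is new, unique, unknown or untested is made for them only; others in the source may bear on it.

Compound 2 `COc1cc(-c2nn(-c3cccc(NC(=O)Nc4ccc(Cl)c(C(F)(F)F)c4)c3)cc2-c2ccncc2)ccc1Cl` gives 890 nM in a functional assay on OVCAR-3 cells (Homo sapiens) for inhibition, read by sulforhodamine B assay, with a stated time of 48 h; on this read-out higher numbers stand for weaker inhibition and lower numbers for stronger inhibition. It stands lowest of the two numbers shown, though compound 1 `O=C(Nc1cccc(-n2cc(-c3ccncc3)c(-c3ccc(Cl)c(O)c3)n2)c1)Nc1ccc(Cl)c(Cl)c1`, which gives 1050 nM, lies within the scatter of it, so the two cannot be ordered. Compound 3 `O=C(Nc1cccc(-n2cc(-c3ccncc3)c(-c3ccc(Cl)c(O)c3)n2)c1)Nc1ccc(Cl)c(C(F)(F)F)c1` differs from compound 2 by hydrogen in place of methyl on an oxygen on an aromatic ring. No step of this kind is shown among the measured compounds. The step of a 1.1-fold higher number from compound 2 to compound 3 (0.03 log units; within the scatter) is expected to stay within the scatter, in no particular direction. Compound 3 is therefore estimated at 950 nM, with a range from 450 nM to 2000 nM.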

Compound 3, half-maximal inhibitory concentration: 830 nM
For compound 3 the middle estimate is 1.1-fold (0.06 log units) above the measured one; the range from low to high includes it.
By their numbers in this assay, from the lowest: compounds 3, 2 and 1 (each within the scatter of the next).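

In this assay, going from methoxy to hydroxy gives a 1.1-fold lower number from compound 2 to compound 3 (0.03 log units; within the scatter), so the two groups cannot be told apart at this position on the shared core. The same holds for a second single change, trifluoromethyl in place of chloro on an aromatic carbon, which gives a 1.3-fold lower number from compound 1 to compound 3 (0.10 log units; within the scatter). Nothing available explains either result. Still open, on these data alone, is whether a longer chain on that oxygen, such as ethoxy, would also stay within the scatter. The same question applies to an amine or a carboxylic acid in place of the hydroxy.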